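Trading Trifluoromethyl for Fluoro on the Sulfonyl Aryl

The source may hold more compounds than are shown below. What is called first, only, known or untested is meant among the compounds shown, and "the series" means these compounds.

Compound 1 `O=S(=O)(NCCCNc1nccc(-c2c(-c3cccc(F)c3)nc3sccn23)n1)c1ccc(C(F)(F)F)cc1` stands second highest of three values in a functional assay on SK-MEL-28 cells (Homo sapiens) for cytotoxicity, read by MTT assay (a lower number here means a stronger inhibitor, a higher number a weaker inhibitor), where compound 1 gives 11700 nM. Compound 2 `O=S(=O)(NCCCNc1nccc(-c2c(-c3cccc(F)c3)nc3sccn23)n1)c1ccc(Cl)cc1` gives 8450 nM, and compound 3 `O=S(=O)(NCCNc1nccc(-c2c(-c3cccc(F)c3)nc3sccn23)n1)c1cccc(F)c1` gives 18300 nM. Compound 4 `O=S(=O)(NCCCNc1nccc(-c2c(-c3cccc(F)c3)nc3sccn23)n1)c1ccc(F)cc1` differs from compound 1 by fluoro in place of trifluoromethyl on an aromatic carbon. Among the measured compounds shown here, the only step that bears on this change is the one at the same aromatic carbon, a 1.4-fold lower number from compound 1 to compound 2 (0.14 log units; within the scatter), which stayed within the scatter; the step of a 2.2-fold higher number from compound 2 to compound 3 (0.34 log units; beyond the scatter) alters the chain and its aryl together and so speaks less directly to it. One therefore expects little movement in this assay beyond the scatter, in either direction. Compound 4 is expected to give 12000 nM, between 5000 nM and 30000 nM, an expected step of a 1.0-fold higher number from compound 1 to compound 4 (0.01 log units; within the scatter).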

Compound 4, half-maximal inhibitory concentration: > 20000 nM
Compound 4: no number, only a limit; the forecaster's own chance of this, stated with the estimate: 10%; middle value at least 1.6-fold (0.22 log units) from the limit.
By their numbers in this assay, from the lowest: compounds 2, 1 and 3 (each within the scatter of the next, the first and the last beyond it). At a limit, above all of these: compound 4.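

In this assay compound 4 gives no number, only a limit: the limit of > 20000 nM in this assay, at which 1 of the 4 values shown sits. The earlier change at this aromatic carbon stayed within the scatter, whereas the step from chloro to fluoro does not (an at least 2.3-fold higher number from compound 2 to compound 4 (0.37 log units; beyond the scatter)), so the group held here can move the read-out. The other two floors fix no separation (an at least 1.7-fold higher number from compound 1 to compound 4 (0.23 log units; that floor lies within the scatter); an at least 1.0-fold higher number from compound 3 to compound 4 (0.03 log units; that floor lies within the scatter)), since both lie within the scatter. On these data alone, how far compound 4 lies past its limit remains open, as does how a methoxy or an amine on this carbon would compare with chloro.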